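The compounds below may be only part of what the source reports. "The series", "measured", "known", "first", "only" and "open" are said of these compounds alone.

Of the compounds shown here, three have been tested in a functional assay on DU-145 cells (Homo sapiens) for inhibition; a lower number here means a stronger inhibitor, a higher number a weaker inhibitor. Compound 1, `Oc1cccc(-c2cc(-c3ccc(F)cc3)cc(-c3ccccc3O)n2)c1`, carries a 3-hydroxyphenyl group on its core. In this assay compound 1 gives only > 50000 nM, which is a limit of the assay and not a number. Compound 2, `Oc1ccc(-c2cc(-c3ccc(F)cc3)cc(-c3ccccc3O)n2)cc1`, differs from compound 1 by 4-hydroxyphenyl in place of 3-hydroxyphenyl on an aromatic carbon. In this assay compound 2 likewise gives only a limit, > 50000 nM. The step that the two limits leave unreadable from compound 1 to compound 2 therefore cannot be read because of the limit of > 50000 nM in this assay, at which 2 of the 3 values shown sit.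

Compound 3, `Oc1cccc(-c2cc(-c3ccccc3C(F)(F)F)cc(-c3cccc(O)c3)n2)c1`, has a different core; how the cores of compound 1 and compound 3 differ is not broken down here. In this assay compound 3 gives 2870 nM, the only numerical result so far.

Compound 4, `Oc1ccc(-c2cc(-c3ccccc3C(F)(F)F)cc(-c3cccc(O)c3)n2)cc1`, has not yet been measured. It differs from compound 3 by 4-hydroxyphenyl in place of 3-hydroxyphenyl on an aromatic carbon. This is the same kind of change as from compound 1 to compound 2, though the surroundings differ: in compound 1 the place is meta to a 2-hydroxyphenyl group and meta to a 4-fluorophenyl group, while in compound 3 it is meta to a 2-(trifluoromethyl)phenyl group and meta to a 3-hydroxyphenyl group. For the measured compounds named here, no measured step of this kind is readable, so the size of the move is uncertain. The expected step, a 1.9-fold higher number from compound 3 to compound 4 (0.28 log units; within the scatter), is estimated as a modest loss since compound 3 gives 2870 nM and serves as the only anchor. Compound 4 is thus expected to reach 5500 nM, likely between 1500 nM and 25000 nM.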

Compound 4, half-maximal inhibitory concentration: 2750 nM
Beside the measured number, compound 4's estimate is 2.0-fold (0.30 log units) above it, within the range that was stated.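

In this assay, 4-hydroxyphenyl in place of 3-hydroxyphenyl gives a 1.0-fold lower number from compound 3 to compound 4 (0.02 log units; within the scatter), so on the core bearing the 2-(trifluoromethyl)phenyl group, the two hydroxyphenyl groups cannot be told apart by this read-out. The same change on the core of compound 1, leading to compound 2, cannot be read, as both of those compounds give a limit of the assay and not a number: the limit of > 50000 nM in this assay, at which 2 of the 4 values shown sit. The series therefore offers only one readable case of this change, which shows that the hydroxyl can sit in either printed arrangement on one core without a difference beyond the scatter, but does not show that the same holds on the other core.

Compound 1 and compound 3 differ in more than one place, so the compounds shown leave open which of those differences separates a limit from a number, including the part played by the 4-fluorophenyl, 2-hydroxyphenyl and 2-(trifluoromethyl)phenyl groups taken one at a time. Also open is what would happen if an amine or a carboxylic acid stood on that ring in place of the hydroxyl, since every compound shown here carries a hydroxyl there.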